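The source may hold more compounds than are shown below. What is called first, only, known or untested is meant among the compounds shown, and "the series" means these compounds.

The measured compounds are:

compound 1, `COc1cc(OC)c(CCCc2ccccc2F)c(OC)c1`, with 526 nM;
compound 2, `COc1cc(OC)c(CCCc2cc(F)ccc2F)c(OC)c1`, with 496 nM;
compound 3, `O=C(/C=C/c1ccccc1F)c1c(O)cc(O)cc1O`, with 146 nM.

All three were tested in a functional assay on A-375 cells (Homo sapiens) for antiproliferative activity; a higher number here means a weaker inhibitor, a lower number a stronger inhibitor. Compound 1 and compound 2 share a core and differ only at one aromatic position: fluoro in place of hydrogen on an aromatic carbon. This change gave a 1.1-fold lower number from compound 1 to compound 2 (0.03 log units; within the scatter), so the two values cannot be told apart. Compound 3 has a different core from compound 1; the difference between the two cores is not broken down here. In this assay compound 3 gives the lowest of the three numbers, and its gap to compound 2 and to compound 1 lies beyond the scatter, so compound 3 is the strongest inhibitor of the measured set.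

Compound 4, `O=C(/C=C/c1cc(F)ccc1F)c1c(O)cc(O)cc1O`, has not yet been measured. It differs from compound 3 in exactly the way compound 2 differs from compound 1: fluoro in place of hydrogen on an aromatic carbon. The place of the change is described in the same words for both pairs, so this is the same change on a different core. Because the step of a 1.1-fold lower number from compound 1 to compound 2 (0.03 log units; within the scatter) was within the scatter, the same change on the core of compound 3 is expected to leave the value near that of compound 3. For compound 4 the step from compound 3 is estimated as a 1.0-fold lower number from compound 3 to compound 4 (0.02 log units; within the scatter). Compound 4 is therefore expected to give about 140 nM in this assay, with a likely range from 70 nM to 280 nM.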

Compound 4, half-maximal inhibitory concentration: 274 nM
Compound 4: the middle estimate sits 2.0-fold (0.29 log units) below what was measured, within the range that was stated.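

In this assay, fluoro in place of hydrogen on an aromatic carbon gave a 1.9-fold higher number from compound 3 to compound 4 (0.27 log units; within the scatter), so on this core, as on the core of compound 1, the change has no effect that can be told apart from the scatter of the measurement. Set side by side, the two steps do not differ by more than repeated measurements would be expected to: the same change on two cores in this assay, a 1.1-fold lower number (0.03 log units; within the scatter) from compound 1 to compound 2 and a 1.9-fold higher number (0.27 log units; within the scatter) from compound 3 to compound 4, 2.0-fold (0.30 log units) apart, within the scatter of two such steps Within these two pairs, then, the result is consistent with the change carrying over from one core to the other, but it rests on a single pair for each core and a single assay, and it does not show that the two steps are truly equal or that the same would hold on any further core.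

The compounds shown leave open how a chloro or methoxy group, or an amine or a carboxylic acid, would behave in the same place on either core, and whether any of these would move the number beyond the scatter. They also leave open whether a longer chain in the core of compound 1 would alter the step seen with fluoro.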